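A few compounds are considered here, and "the series" means these few. Any claim that something is new, unique, unknown or untested is made for them only; others in the source may bear on it.

In a functional assay (aorta) with Oryctolagus cuniculus as the target (on this read-out higher numbers stand for weaker inhibition and lower numbers for stronger inhibition), compound 2 `COCCO/C(O)=C1\C(C)=NC(C)=C(C(=O)OCCCN2C(=O)c3ccccc3S2(=O)=O)C1c1ccccc1[N+](=O)[O-]` gives 2.7 nM, and compound 1 `CCO/C(O)=C1\C(C)=NC(C)=C(C(=O)OCCCN2C(=O)c3ccccc3S2(=O)=O)C1c1ccccc1[N+](=O)[O-]` gives 2.6 nM, so the two numbers sit within the scatter of each other and neither stands apart. Compound 3 `CC1=NC(C)=C(C(=O)OCCCN2C(=O)c3ccccc3S2(=O)=O)C(c2ccccc2[N+](=O)[O-])/C1=C(\O)OCC1CCCO1` differs from compound 2 by oxolan-2-yl in place of methoxymethyl on a saturated chain carbon bound to an oxygen on an unsaturated carbon. For the measured compounds named here, the one measured step on this chain, a 1.0-fold higher number from compound 1 to compound 2 (0.02 log units; within the scatter), changed nothing beyond the scatter, and no measured step brings a ring into this position. A step no larger than the scatter is therefore expected, a 1.1-fold higher number from compound 2 to compound 3 (0.05 log units; within the scatter). Compound 3 is estimated at 3 nM, with a range from 1.2 nM to 8 nM.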

Compound 3, half-maximal inhibitory concentration: 6.8 nM
The estimate for compound 3 lay 2.3-fold (0.36 log units) below the measured number; the range from low to high includes it.
By their numbers in this assay, from the lowest: compounds 1 and 2 (each within the scatter of the next); then compound 3.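

The chain position that took methoxy with no change beyond the scatter does respond to a ring: in this assay, oxolan-2-yl in place of methoxymethyl gives a 2.5-fold higher number from compound 2 to compound 3 (0.40 log units; beyond the scatter) and oxolan-2-yl in place of methyl gives a 2.6-fold higher number from compound 1 to compound 3 (0.42 log units; beyond the scatter), two steps of modest size. So the position accepts some changes more readily than others. Nothing available here explains the shift.

Whether the ring itself or simply the larger group lies behind the higher number stays open. Going by these compounds, a longer open chain such as butyl would help separate the two, and how a chain ending in an amine would read is also open.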